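The source may report more compounds than this note shows. Statements on the series, on what has been measured and on what is new or still open speak of the compounds shown alone.

Compound 1 `COC(=O)c1c(-c2cc(OC)cc(OC)c2)oc2ccccc2c1=O` gives > 25 ug/mL in a functional assay on A549 cells (Homo sapiens) for cytotoxicity, read by MTT assay, with a stated time of 6 days; a lower number here means that less compound is needed, a higher number that more compound is needed for the effect. Compound 2 `COC(=O)c1c(-c2ccc([N+](=O)[O-])cc2)oc2ccccc2c1=O` gives > 25 ug/mL in this assay. Compound 3 `COc1cc(OC)cc(-c2oc3ccccc3c(=O)c2C(=O)O)c1` gives > 25 ug/mL in this assay.

Each of these three values is a limit of the assay, not a measured number, and this is the whole picture: the limit of > 25 ug/mL in this assay, at which 3 of the 3 values shown sit. Compound 1 and compound 3 differ by hydrogen in place of methyl on an oxygen next to a carbonyl group. Between them lies a step that the two limits leave unreadable from compound 1 to compound 3. Compound 2 and compound 1 differ in their cores, and that difference is not broken down here.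

Compound 4 `O=C(O)c1c(-c2ccc([N+](=O)[O-])cc2)oc2ccccc2c1=O` has not yet been measured in this assay. Among the measured compounds shown here, it differs from compound 2 by hydrogen in place of methyl on an oxygen next to a carbonyl group, the same change as the one from compound 1 to compound 3, made at a place described in the same words. The earlier step gives no readable size, so the expectation rests only on the limits. Compound 4 is expected to show a step that the limit leaves unreadable from compound 2 to compound 4 in this assay, a step that is likely to stay unreadable, since all three measured values sit at the limit (the limit of > 25 ug/mL in this assay, at which 3 of the 3 values shown sit). The estimate for compound 4 is 40 ug/mL, between 15 ug/mL and 150 ug/mL.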

Compound 4, concentration for half-maximal effect: > 25 ug/mL
Compound 4: no number, only a limit; the forecaster's own chance of this, stated with the estimate: 80%; the middle value does not contradict the limit.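

In this assay compound 4 gives > 25 ug/mL, which is a limit and not a number. Compound 2 also sits at a limit, so no step can be read between compound 2 and compound 4. The compounds shown leave open how much of any of them would give the effect, because all values sit at one limit: the limit of > 25 ug/mL in this assay, at which 4 of the 4 values shown sit.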